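The source may hold more compounds than are shown below. What is called first, only, known or untested is meant among the compounds shown, and "the series" means these compounds.

Measured in a functional assay on KB cells (Homo sapiens) for antiproliferative activity, read by MTT assay, with a stated time of 72 h; a lower number here means a stronger inhibitor, a higher number a weaker inhibitor:
- Compound 1 `CCOC(=O)c1cc(-c2cc(OC)c(OC)c(OC)c2)c(-c2ccc(OC)cc2)s1`: 13200 nM
- Compound 2 `COc1ccc(-c2sc(C(=O)O)cc2-c2cc(OC)c(OC)c(OC)c2)cc1`: 10400 nM
- Compound 3 `COc1ccc(-c2sc(C(=O)O)cc2-c2cc(OC)c(OC)c(OC)c2)cc1[N+](=O)[O-]`: 35900 nM

Compound 2 is level with compound 1, since hydrogen in place of ethyl on an oxygen next to a carbonyl group gives a 1.3-fold lower number from compound 1 to compound 2 (0.10 log units; within the scatter). Only compound 3 stands apart, with nitro in place of hydrogen on an aromatic carbon giving a 3.5-fold higher number from compound 2 to compound 3 (0.54 log units; beyond the scatter).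

The next compound, compound 4 `COc1cc(-c2cc(C(=O)O)sc2-c2ccc3ccccc3c2)cc(OC)c1OC`, has naphthalen-2-yl in place of 4-methoxyphenyl, next to the ring sulfur: naphthalen-2-yl in place of 4-methoxyphenyl on an aromatic carbon. The nitro step is the closer guide, as it was made on the same 4-methoxyphenyl group, and it was modest. The step at the ester lies elsewhere on the molecule and says little here. Neither shows what replacing the whole group does, so no direction can be claimed, and no step beyond the scatter is expected, though the uncertainty runs wide both ways. The expected change is a 1.2-fold lower number from compound 2 to compound 4 (0.06 log units; within the scatter). The estimate for compound 4 is 9000 nM, with an expected range from 2500 nM to 35000 nM.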

Compound 4, half-maximal inhibitory concentration: 5640 nM
Beside the measured number, compound 4's estimate is 1.6-fold (0.20 log units) above it, within the range that was stated.
By their numbers in this assay, from the lowest: compounds 4, 2 and 1 (each within the scatter of the next, the first and the last beyond it); then compound 3.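

Naphthalen-2-yl in place of 4-methoxyphenyl gives a 1.8-fold lower number from compound 2 to compound 4 (0.27 log units; within the scatter) in this assay and this is the first look at replacing the whole group on the aromatic carbon next to the ring sulfur. The earlier nitro step only added to the 4-methoxyphenyl group, and it raised the number beyond the scatter. Here, a group with two six-membered aromatic rings of carbon only and no hydrogen-bond acceptor stands in for one with a single such ring and one acceptor, and the number stays within the scatter, though no measurement at hand accounts for this.

Still open, from the compounds shown here alone, is whether an amine on the 4-methoxyphenyl group would move the number as nitro does. A plain methyl group at this place, or naphthalen-2-yl paired with the ethyl ester, could also behave differently.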